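Notes on two measured compounds and one unmeasured bromo analogue

The compounds below may be only part of what the source reports. "The series", "measured", "known", "first", "only" and "open" are said of these compounds alone.

compound 1 `Cc1c(C(=O)N/N=C/c2ccc(N(C)C)cc2)no[n+]1[O-]`: 22%
compound 2 `Cc1c(C(=O)N/N=C/c2ccc([N+](=O)[O-])o2)no[n+]1[O-]`: 13%

In a functional assay on the whole organism (Abdomen, strain albino) for inhibition, with Mus musculus as the target, with stated times of 1 h and 60 min, at a dose of 100 umol/kg by the oral route (a higher number here means more inhibition at the dose given (going by the name of the read-out), a lower number less inhibition), compound 1 gives 22%, the higher of the two numbers, while compound 2 gives 13%; the gap lies within the scatter, so the two are not ordered. Compound 3 `Cc1c(C(=O)N/N=C/c2ccc(Br)cc2)no[n+]1[O-]` differs from compound 1 by bromo in place of dimethylamino on an aromatic carbon. Within the data shown here, no step between measured compounds covers this change, and both measured numbers sit low, so the expected step from compound 1 to compound 3 is none beyond the scatter, a number 4 percentage points lower from compound 1 to compound 3 (within the scatter). Compound 3 is therefore estimated at 18%, in the range 5% to 32%.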

Compound 3, a percentage reported as inhibition, in the whole organism at one dose (the size of the read-out at that dose, not a potency): 23%
Beside the measured number, compound 3's estimate is 5 percentage points below it, and the stated range covers the measured number.
By their numbers in this assay, from the lowest: compounds 2, 1 and 3 (each within the scatter of the next).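

In this assay, bromo in place of dimethylamino on an aromatic carbon, para to a large group, gives a number 1 percentage points higher from compound 1 to compound 3 (within the scatter), so the read-out does not separate these two groups at this position. Dimethylamino, with its heavier count of atoms and its hydrogen-bond acceptor, is thus not required for the inhibition seen at this dose, and a single bromine atom serves as well.

As far as these compounds go, whether a carboxylic acid or a methoxy group on the same carbon would read beyond the scatter stays open. Nothing at hand speaks to why the two groups read alike.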